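Swapping a Nitro Group for an Ethoxy Group

The compounds below may be only part of what the source reports. "The series", "measured", "known", "first", "only" and "open" are said of these compounds alone.

Three measured compounds share one core. Compound 1 `COc1cccc(OC)c1OCCNCCOc1ccccc1OCc1ccccc1` gives 8.39 in a functional assay on Vas deferens for antagonist activity at Alpha-1A adrenergic receptor (Rattus norvegicus) (on this read-out lower numbers stand for lower potency and higher numbers for higher potency (the scale is a negative logarithm)), compound 2 `COc1cccc(OC)c1OCCNCCOc1ccccc1OCc1ccc(Cl)cc1` gives 8.17, and compound 3 `COc1cccc(OC)c1OCCNCCOc1ccccc1OCc1cccc([N+](=O)[O-])c1` gives 8.85, the highest of the three. Compound 4 `CCOc1ccc(COc2ccccc2OCCNCCOc2c(OC)cccc2OC)cc1` has not yet been measured. The change from compound 3 is 4-ethoxyphenyl in place of 3-nitrophenyl on a saturated chain carbon bound to an oxygen on an aromatic ring. Among the measured compounds shown here, two measured steps bear on this change: a number 0.46 log units higher from compound 1 to compound 3 (beyond the scatter), and a number 0.68 log units higher from compound 2 to compound 3 (beyond the scatter), while a number 0.22 log units lower from compound 1 to compound 2 (within the scatter). Taking the nitro group away has so far gone with lower numbers, and putting a chloro group in its stead did not bring them back, so a modest drop is expected, a number 0.55 log units lower from compound 3 to compound 4 (beyond the scatter). Compound 4 is therefore estimated at 8.3, with a range from 7.8 to 8.8.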

Compound 4, negative logarithm of the antagonist equilibrium constant: 8.5
For compound 4 the middle estimate is 0.20 log units below the measured one, within the range that was stated.
By their numbers in this assay, from the lowest: compounds 2, 1 and 4 (each within the scatter of the next, the first and the last beyond it); then compound 3.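

Replacing 3-nitrophenyl with 4-ethoxyphenyl at this position gives a real loss (a number 0.35 log units lower from compound 3 to compound 4 (beyond the scatter)), so compound 3 stays on top in this assay. The ethoxy group still separates from chloro (a number 0.33 log units higher from compound 2 to compound 4 (beyond the scatter)), while against plain hydrogen it makes no clear difference (a number 0.11 log units higher from compound 1 to compound 4 (within the scatter)), so the nitro group is the only substituent here that lifts the number above the unsubstituted compound 1. No data here explain these differences.

Still open, from the compounds shown here alone, is whether 4-nitrophenyl would match 3-nitrophenyl, and how an amine or a carboxylic acid on this ring would read.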